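Moving the methyl on the urea aryl ring of compound 1

The compounds below may be only part of what the source reports. "The series", "measured", "known", "first", "only" and "open" are said of these compounds alone.

Compound 1 `Cc1ccc(NC(=O)Nc2cccc(CNc3nccnc3Cl)c2)cc1` was tested in a functional assay on T-24 cells (Homo sapiens) for antiproliferative activity, read by MTT assay, with a stated time of 48 h (a higher number here means a weaker inhibitor, a lower number a stronger inhibitor), where compound 1 gives 9820 nM. Among the measured compounds shown here, its only measured neighbour is compound 2 `CCOc1ccc(NC(=O)Nc2cccc(CNc3nccnc3Cl)c2)cc1`, which in this assay gives 9080 nM; the two stand together, since the step of a 1.1-fold lower number from compound 1 to compound 2 (0.03 log units; within the scatter) lies within the scatter. Compound 3 `Cc1ccccc1NC(=O)Nc1cccc(CNc2nccnc2Cl)c1` is not yet measured. It differs from compound 1 in one place: 2-methylphenyl in place of 4-methylphenyl on an amide-type nitrogen. For the measured compounds named here, no measured step of this set alters the methylphenyl ring itself; the single step available, from compound 1 to compound 2, swaps the group on an aromatic carbon and stays within the scatter, so it bears only loosely on this change. With nothing pointing in either direction, compound 3 is expected to stay near compound 1, with the step of a 1.0-fold higher number from compound 1 to compound 3 (0.01 log units; within the scatter) estimated to fall within the scatter. In this assay compound 3 is therefore estimated at 10000 nM, within a range from 4000 nM to 30000 nM.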

Compound 3, half-maximal inhibitory concentration: 13600 nM
Estimate against measurement, compound 3: 1.4-fold (0.13 log units) below, within the range that was stated.
By their numbers in this assay, from the lowest: compounds 2, 1 and 3 (each within the scatter of the next).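

Moving the methyl on the ring attached to the amide-type nitrogen, with 2-methylphenyl in place of 4-methylphenyl, gives in this assay a 1.4-fold higher number from compound 1 to compound 3 (0.14 log units; within the scatter) and so leaves compound 3 together with compound 1. Compound 3 also stands with the ethoxy compound, the change from 4-ethoxyphenyl to 2-methylphenyl giving a 1.5-fold higher number from compound 2 to compound 3 (0.18 log units; within the scatter) and so showing that this position tolerates a change in both the place and the identity of the group without leaving the scatter. No measurement is available that would explain these numbers.

The compounds shown leave open whether any group on this ring can separate from these values, such as an amine or a carboxylic acid in place of the methyl. They also leave open how 3-methylphenyl would compare.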